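Swapping Trifluoromethoxy for Chloro in a Urea Series

The source may report more compounds than this note shows. Statements on the series, on what has been measured and on what is new or still open speak of the compounds shown alone.

Compound 1, `O=C(Nc1ccc(C(F)(F)F)cc1)N1CCN(c2ncccc2Cl)CC1`: 63.5 nM
Compound 2, `O=C(Nc1ccc(OC(F)(F)F)cc1)N1CCN(c2ncccc2Cl)CC1`: 93.2 nM

In a functional assay on HEK293 cells for antagonist activity at transient receptor potential cation channel subfamily V member 1 (Rattus norvegicus) (on this read-out lower numbers stand for stronger inhibition and higher numbers for weaker inhibition), compound 1 gives 63.5 nM while compound 2 gives 93.2 nM, the higher of the two numbers, and the step of a 1.5-fold higher number from compound 1 to compound 2 (0.17 log units; within the scatter) lies within the scatter. Compound 3, `O=C(Nc1ccc(Cl)cc1)N1CCN(c2ncccc2Cl)CC1`, differs from compound 2 by chloro in place of trifluoromethoxy on an aromatic carbon. Among the compounds with values here, the one measured step touches the same position but swaps two groups unlike this pair, so it offers only weak guidance; a modest loss in this assay is expected for compound 3. Compound 3 is estimated at 160 nM, between 55 nM and 480 nM, an expected step of a 1.7-fold higher number from compound 2 to compound 3 (0.23 log units; within the scatter).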

Compound 3, half-maximal inhibitory concentration: 655 nM
The estimate for compound 3 lay 4.1-fold (0.61 log units) below the measured number; measured number above the stated range.
By their numbers in this assay, from the lowest: compounds 1 and 2 (each within the scatter of the next); then compound 3.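

Trifluoromethoxy and trifluoromethyl gave numbers within the scatter of each other, but chloro at this position separates clearly from both in this assay: a 7.0-fold higher number from compound 2 to compound 3 (0.85 log units; beyond the scatter), and a 10-fold higher number from compound 1 to compound 3 (1.01 log units; beyond the scatter). The position therefore distinguishes among these groups, which the earlier pair alone could not show. Nothing available accounts for this loss. Going by these compounds, whether a methyl, a nitrile or a methoxy here would fall nearer chloro or nearer the two fluorine-bearing groups stays open, as does whether this order holds on another core.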